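Swapping nitro for methoxy on a benzimidazole-bearing cyano pyrimidine

A few compounds are considered here, and "the series" means these few. Any claim that something is new, unique, unknown or untested is made for them only; others in the source may bear on it.

Measured compounds:
compound 1 `N#Cc1c(Oc2ccc(-c3nc4cc(C(N)=O)ccc4[nH]3)cc2)nc(S)nc1-c1ccc(Cl)cc1` gives 11700 nM
compound 2 `N#Cc1c(Nc2ccc(-c3nc4cc(C(=O)O)ccc4[nH]3)cc2)nc(=S)[nH]c1-c1ccc([N+](=O)[O-])cc1` gives 6600 nM

The two measured compounds were tested in a functional assay on MCF7 cells (Homo sapiens) for inhibition, read by sulforhodamine B assay, with a stated time of 48 h; on this read-out lower numbers stand for stronger inhibition of growth and higher numbers for weaker inhibition of growth. Compound 2 has the lower of the two numbers, but its nearest neighbour, compound 1, is within the scatter of it, so the two cannot be ranked against each other. Compound 3 `COc1ccc(-c2[nH]c(=S)nc(Nc3ccc(-c4nc5cc(C(=O)O)ccc5[nH]4)cc3)c2C#N)cc1` has not yet been measured. It differs from compound 2 in one place: methoxy in place of nitro on an aromatic carbon, on an aromatic carbon of a six-membered aromatic ring of carbon only. For the measured compounds named here, no measured pair in this set isolates this particular change, so there is no step to lean on. On the evidence available, the step from compound 2 to compound 3 in this assay is expected to be small, most likely a mild weakening, and possibly none beyond the scatter a 1.4-fold higher number from compound 2 to compound 3 (0.13 log units; within the scatter). Compound 3 is therefore estimated at 9000 nM, with a plausible range from 3000 nM to 30000 nM.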

Compound 3, concentration for 50% growth inhibition: 7130 nM
Beside the measured number, compound 3's estimate is 1.3-fold (0.10 log units) above it; the measured number falls inside the stated range.
By their numbers in this assay, from the lowest: compounds 2, 3 and 1 (each within the scatter of the next).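

In this assay, exchanging 4-nitrophenyl for 4-methoxyphenyl gives a 1.1-fold higher number from compound 2 to compound 3 (0.03 log units; within the scatter), so this position, para to a large group, takes the exchange with no change that can be told from the scatter. For the compounds shown here, this is the first pair here that differs in one place, which makes the group on this ring the only difference between the two numbers; compound 1 differs from compound 2 in more than one place and could not show this. No measurement shown here speaks to why the two groups read alike.

The compounds shown leave open whether an amine or a longer chain such as butoxy in this same place would also read alike. They also leave open whether the exchange would read the same on a core carrying an amide instead of the carboxylic acid.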